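Swapping dimethylphenyl for trihydroxyphenyl on the chain

The compounds below may be only part of what the source reports. "The series", "measured", "known", "first", "only" and "open" are said of these compounds alone.

Values measured in a functional assay on DU-145 cells (Homo sapiens) for inhibition, read by trypan blue exclusion, with a stated time of 96 h (on this read-out lower numbers stand for stronger inhibition of growth and higher numbers for weaker inhibition of growth), are as follows
Compound 1 `Cc1ccc(C)c(/C=C(/Sc2ccc(Br)cc2)C(=O)c2ccc(Cl)cc2)c1` gives 10000 nM
Compound 2 `Cc1ccc(CS/C(=C/c2cc(C)ccc2C)C(=O)c2ccc(Cl)cc2)cc1` gives 10000 nM
Compound 3 `CN(C)c1ccc(/C=C(/SCc2ccc(Br)cc2)C(=O)c2ccc(C(=O)O)cc2)cc1` gives 50000 nM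

Compound 2 stands level with compound 1, the pair holding the lowest of the three numbers, with compound 3 furthest off. Compound 4 `Cc1ccc(CS/C(=C/c2ccc(O)c(O)c2O)C(=O)c2ccc(Cl)cc2)cc1` differs from compound 2 by 2,3,4-trihydroxyphenyl in place of 2,5-dimethylphenyl on a double-bonded chain carbon bound to a double-bonded chain carbon with 2,3,4-trihydroxyphenyl in place of 2,5-dimethylphenyl on a double-bonded chain carbon bound to a double-bonded chain carbon. Within the data shown here, the only measured step is no change at the digits printed from compound 1 to compound 2 (within the scatter) (4-methylbenzyl in place of 4-bromophenyl on a sulfur), which leaves the 2,5-dimethylphenyl group untouched and so gives no direct guide. In this assay no step beyond the scatter is therefore expected, and the estimated change is a 1.4-fold lower number from compound 2 to compound 4 (0.15 log units; within the scatter) at the middle of a wide range. Compound 4 is expected at 7000 nM within an estimated range of 1500 nM to 30000 nM in this read-out.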

Compound 4, concentration for 50% growth inhibition: 50000 nM
Compound 4: middle estimate off by 7.1-fold (0.85 log units), on the low side; measured number above the stated range.
By their numbers in this assay, from the lowest: compounds 1 and 2 (each within the scatter of the next); then compounds 3 and 4 (each within the scatter of the next).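

In this assay, the group on a double-bonded chain carbon bound to a double-bonded chain carbon does move the read-out, unlike the earlier change on the sulfur: 2,3,4-trihydroxyphenyl in place of 2,5-dimethylphenyl gives a 5.0-fold higher number from compound 2 to compound 4 (0.70 log units; beyond the scatter). Growth inhibition weakens as three hydrogen-bond donors and three acceptors enter where the old group had none. Nothing available explains this result.

On these data alone, whether all three hydroxyl groups are needed for the loss remains open. So does how methoxy groups or an amine on this ring would read.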